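The source may report more compounds than this note shows. Statements on the series, on what has been measured and on what is new or still open speak of the compounds shown alone.

Measured compounds:
- compound 1 `Cc1cc(C)nc(Oc2ccc(NC(=O)Nc3ccccc3)cc2)n1` — "not determined" (no result reported)
- compound 2 `Cc1cccc(NC(=O)Nc2ccc(Oc3nc(C)cc(C)n3)cc2)c1` — "not determined" (no result reported)
- compound 3 `Cc1cc(C)nc(Oc2ccc(NC(=O)Nc3ccc(OC(F)(F)F)cc3)cc2)n1` — > 50000 nM

All three share one core, a diaryl urea carrying a substituted pyrimidine ether, and differ only in the group on the outer phenyl ring. The read-out is a functional assay on MCF7 cells (Homo sapiens) for cytotoxicity, read by MTT assay, with a stated time of 3 days; on this read-out higher numbers stand for weaker inhibition and lower numbers for stronger inhibition. For compound 1 and compound 2 no result was reported in this assay at all. For compound 3 only a limit is known: in this assay compound 3 gives > 50000 nM, which is a limit of the assay and not a number. For the measured compounds named here, the only piece of evidence on this series is the limit of > 50000 nM in this assay, at which 1 of the 3 values shown sits. So compound 3 stands as the single entry with any figure, and that figure is a limit.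

Compound 4 `Cc1cc(C)nc(Oc2ccc(NC(=O)Nc3ccc(F)cc3)cc2)n1` is not yet measured. It differs from compound 3 in one place: fluoro in place of trifluoromethoxy on an aromatic carbon. Going by the values given here, no step between two measured compounds exists here, so there is no measured change to lean on. Because compound 3 sits at the limit > 50000 nM, the step that the limit leaves unreadable from compound 3 to compound 4 is expected to be none beyond the scatter. Compound 4 is therefore expected to give about 60000 nM, within a range from 20000 nM to 200000 nM, and most likely to be reported again only as a limit.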

Compound 4, half-maximal inhibitory concentration: > 50000 nM
Compound 4 was reported as a limit; the forecaster's own chance of this, stated with the estimate: 80%; the middle value is on the limit's open side.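

In this assay compound 4 gives > 50000 nM, which is a limit of the assay and not a number. Compound 3 is also known only as a limit, so the change between compound 3 and compound 4 cannot be read. What the compounds shown leave open is whether any group on the outer phenyl ring gives an actual number in this assay.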